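Ethyl for piperidin-4-yl in the series

The source may hold more compounds than are shown below. What is called first, only, known or untested is meant among the compounds shown, and "the series" means these compounds.

Values in a functional assay on HCT-116 cells (Homo sapiens) for cytotoxicity, with a stated time of 48 h; on this read-out lower numbers stand for stronger inhibition of growth and higher numbers for weaker inhibition of growth:
- compound 1 `Nc1nc(-c2cc(N3C[C@H](O)[C@@H](O)C3)ccc2O)cc(C2CCCCCC2)n1`: 300 nM
- compound 2 `Nc1nc(NC2CCCCC2)cc(-c2cc(N3C[C@H](O)[C@@H](O)C3)ccc2O)n1`: 900 nM
- compound 3 `Nc1nc(-c2cc(N3C[C@H](O)[C@@H](O)C3)ccc2O)cc(C2CCNCC2)n1`: > 10000 nM

Compound 3 gives > 10000 nM, which is a limit of the assay and not a number. Compound 4 `CCc1cc(-c2cc(N3C[C@H](O)[C@@H](O)C3)ccc2O)nc(N)n1` carries ethyl in place of piperidin-4-yl on an aromatic carbon. Among the measured compounds shown here, two measured steps bear on this change at the same place: an at least 33-fold higher number from compound 1 to compound 3 (1.52 log units; beyond the scatter) and an at least 11-fold higher number from compound 2 to compound 3 (1.04 log units; beyond the scatter). Both were large, while a 3.0-fold higher number from compound 1 to compound 2 (0.48 log units; beyond the scatter) was modest. For the measured compounds named here, no measured compound carries ethyl, so only a partial return toward those two values is expected. In this assay the expected step is an at least 4.0-fold lower number from compound 3 to compound 4 (0.60 log units; beyond the scatter), toward a lower number. Compound 4 is estimated at 2500 nM, with an expected range of 700 nM to 9000 nM.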

Compound 4, concentration for 50% growth inhibition: 1000 nM
Estimate against measurement, compound 4: 2.5-fold (0.40 log units) above, within the range that was stated.
By their numbers in this assay, from the lowest: compound 1; then compounds 2 and 4 (each within the scatter of the next). At a limit, above all of these: compound 3.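

Compound 3 stands at a limit of the assay and not at a number: the limit of > 10000 nM in this assay, at which 1 of the 4 values shown sits. In this assay, ethyl in place of piperidin-4-yl gives an at least 10-fold lower number from compound 3 to compound 4 (1.00 log units; beyond the scatter), so no ring is needed at this place for a measurable value. Ethyl and cyclohexylamino cannot be told apart, with a 1.1-fold higher number from compound 2 to compound 4 (0.05 log units; within the scatter), whereas cycloheptyl remains ahead of ethyl, with a 3.3-fold higher number from compound 1 to compound 4 (0.52 log units; beyond the scatter).

Still open, as far as these compounds go, is whether the ring nitrogen of piperidin-4-yl, rather than the ring itself, goes with the limit; a plain cyclohexyl would separate the two. Also open, from the compounds shown here alone, is whether a longer chain such as butyl closes the gap from ethyl to cycloheptyl.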